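Bromo to ethoxy on the shared core

The source may report more compounds than this note shows. Statements on the series, on what has been measured and on what is new or still open speak of the compounds shown alone.

Measured in a functional assay on MCF7 cells (Homo sapiens) for inhibition, with a stated time of 48 h (a lower number here means a stronger inhibitor, a higher number a weaker inhibitor), so far
- compound 1 `COc1cc(Sc2c(C)[nH]c3ccccc23)cc(OC)c1OC` gives 46 nM
- compound 2 `COc1cc(Sc2c[nH]c3ccc(Br)cc23)cc(OC)c1OC` gives 43 nM

Compound 1 and compound 2 lie within the scatter of each other, with compound 2 at 43 nM in this pair. Compound 3 `CCOc1ccc2[nH]cc(Sc3cc(OC)c(OC)c(OC)c3)c2c1` has ethoxy in place of bromo on an aromatic carbon and otherwise matches compound 2. Within the data shown here, no measured step covers this change, so the expectation is only a working one. The expected step of a 2.1-fold higher number from compound 2 to compound 3 (0.32 log units; beyond the scatter) is a modest one towards weaker inhibition in this assay and may stay within the scatter. For compound 3 the estimated value is 90 nM with an expected range of 30 nM to 300 nM for now.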

Compound 3, half-maximal inhibitory concentration: 16 nM
Beside the measured number, compound 3's estimate is 5.6-fold (0.75 log units) above it; measured number outside the range, below it.
By their numbers in this assay, from the lowest: compound 3; then compounds 2 and 1 (each within the scatter of the next).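

On this aromatic carbon, ethoxy in place of bromo gives a 2.7-fold lower number from compound 2 to compound 3 (0.43 log units; beyond the scatter) in this assay. The position therefore accepts ethoxy without loss, and the change goes towards stronger inhibition, which the within-scatter pair of compound 1 and compound 2 could not show. Nothing available accounts for this step.

A single pair does not say whether the step goes with the oxygen or with the chain. Methoxy, a longer chain such as propoxy, or an amine on this carbon would separate these readings.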